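Nitrooxyphenyl variant of the hydrazone aryl on the shared core

The source may report more compounds than this note shows. Statements on the series, on what has been measured and on what is new or still open speak of the compounds shown alone.

Measured so far:
compound 1 `CN(C)CCn1cnnc1-c1cc(Oc2ccc(NC(=O)N/N=C/c3ccc(Cl)cc3Cl)cc2F)ccn1` gives 130 nM
compound 2 `COc1ccc(/C=N/NC(=O)Nc2ccc(Oc3ccnc(-c4nncn4CCN(C)C)c3)c(F)c2)c(OC)c1` gives 1570 nM
compound 3 `COc1ccc(/C=N/NC(=O)Nc2ccc(Oc3ccnc(-c4nncn4CCN(C)C)c3)c(F)c2)c(OC)c1OC` gives 1790 nM

In a functional assay on NCI-H460 cells (Homo sapiens) for cytotoxicity, read by MTT assay, with a stated time of 72 h (on this read-out lower numbers stand for stronger inhibition and higher numbers for weaker inhibition), compound 1 stands lowest of the three numbers. Both measured exchanges of the aryl on the carbon with a double bond to nitrogen raised the number a lot: a 12-fold higher number from compound 1 to compound 2 (1.08 log units; beyond the scatter) and a 14-fold higher number from compound 1 to compound 3 (1.14 log units; beyond the scatter). The added methoxy in a 1.1-fold higher number from compound 2 to compound 3 (0.06 log units; within the scatter) changed nothing beyond the scatter.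

Compound 4 `CN(C)CCn1cnnc1-c1cc(Oc2ccc(NC(=O)N/N=C/c3ccccc3O[N+](=O)[O-])cc2F)ccn1` differs from compound 1 by 2-(nitrooxy)phenyl in place of 2,4-dichlorophenyl on a carbon with a double bond to nitrogen. The two steps that bear on it both replace the same 2,4-dichlorophenyl and both were large rises, though neither brings in a nitrooxy group. Compound 4 is therefore expected at 800 nM (range 250 nM to 2500 nM), an expected step of a 6.2-fold higher number from compound 1 to compound 4 (0.79 log units; beyond the scatter).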

Compound 4, half-maximal inhibitory concentration: 1270 nM
For compound 4 the middle estimate is 1.6-fold (0.20 log units) below the measured one; low and high end bracket the measured number.
By their numbers in this assay, from the lowest: compound 1; then compounds 4, 2 and 3 (each within the scatter of the next).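

In this assay, among these compounds, the 2-(nitrooxy)phenyl group also fails to hold the number of the 2,4-dichlorophenyl group, with a 9.8-fold higher number from compound 1 to compound 4 (0.99 log units; beyond the scatter) as the first step here to an aryl carrying neither chlorine nor methoxy. The number at this position therefore rises with all three replacements shown. The nitrooxy aryl is not separated from the methoxy aryls, with a 1.2-fold lower number from compound 2 to compound 4 (0.09 log units; within the scatter) and a 1.4-fold lower number from compound 3 to compound 4 (0.15 log units; within the scatter) on this read-out. No measured evidence on the cause of these steps is available.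

Open, as far as these compounds go, is whether an unsubstituted phenyl, a 4-chlorophenyl or a 2-hydroxyphenyl on this carbon would stay with compound 1 or join compounds 2, 3 and 4.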